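Trimming the urea on a sulfonyl side chain

This account rests on a few compounds, and the source may have more. Where it says the series, first, only, none or still open, it means among the compounds named here.

Compound 2 `CC(C)(C)NC(=O)NCCS(=O)(=O)NC(=O)c1ccc(Nc2nc(NC3(c4ccc(Cl)cc4)CC3)nc(OCC(F)(F)F)n2)cc1` carries a shared core with a sulfonyl side chain that ends in a urea. In an ADME assay on microsomes from liver (Rattus norvegicus) for metabolic stability, with a stated time of 10 min (on this read-out lower numbers stand for a less stable compound and higher numbers for a more stable compound), compound 2 gives 93%. Among the measured compounds shown here, the only other measured compound, compound 1 `Cc1ccccc1S(=O)(=O)NC(=O)c1ccc(Nc2nc(NC3(c4ccc(Cl)cc4)CC3)nc(OCC(F)(F)F)n2)cc1`, gives 100% in this assay, and the step of a number 7 percentage points lower from compound 1 to compound 2 (within the scatter) lies within the scatter, so the two values stand at about the same height, with most of either compound still present after the stated time.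

Compound 3 `CC(C)C(=O)NCCS(=O)(=O)NC(=O)c1ccc(Nc2nc(NC3(c4ccc(Cl)cc4)CC3)nc(OCC(F)(F)F)n2)cc1` differs from compound 2 by isopropyl in place of (tert-butyl)amino on a carbonyl carbon, and nothing else in the molecule changes. For the measured compounds named here, no measured step touches this carbonyl carbon. Going by the values given here, the single step that has been measured concerns the sulfonyl sulfur, where a much larger exchange of groups moved the read-out only within the scatter, and it is the only guide available. On that basis the change to compound 3 is expected to bring no shift beyond the scatter in this assay. Compound 3 is therefore estimated to give 90%, within a range from 72% to 100%. The expected step is a number 3 percentage points lower from compound 2 to compound 3 (within the scatter), which stays within the scatter.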

Compound 3, percent of the compound remaining: 84%
The estimate for compound 3 lay 6 percentage points above the measured number; the range from low to high includes it.
By their numbers in this assay, from the lowest: compounds 3, 2 and 1 (each within the scatter of the next, the first and the last beyond it).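

Among the compounds shown here, compound 3 gives the only reading so far for a change on this carbonyl carbon: in this assay, isopropyl in place of (tert-butyl)amino gives a number 9 percentage points lower from compound 2 to compound 3 (within the scatter), so this exchange does not separate the two compounds. Set against the 2-methylphenyl group on the sulfonyl sulfur, however, the new side chain gives a number 16 percentage points lower from compound 1 to compound 3 (beyond the scatter), the only step here to pass beyond the scatter, whereas the side chain of compound 2 stayed within it, so a change at the sulfur can register in this assay, though only modestly. The data offer no measured explanation for either step.

For the compounds shown here, still open is how this carbonyl carbon would respond to quite different groups, such as a methoxy group, a cyclopropyl ring or a free amine, since only two neighbouring groups can be compared here. Also open, from the compounds shown here alone, is whether a longer chain between the carbonyl carbon and the sulfonyl sulfur, or a carboxylic acid at the end of the side chain, would move the read-out further than the modest step seen so far.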